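The source may report more compounds than this note shows. Statements on the series, on what has been measured and on what is new or still open speak of the compounds shown alone.

Measured compounds:
- compound 1, `COc1cccc(/C=C/C(=O)/C=C/c2ccc(OCc3cn(CCCCOc4cc(=O)oc5ccccc45)nn3)c(OC)c2)c1`: 44%
- compound 2, `COc1cc(/C=C/C(=O)/C=C/c2ccccc2)ccc1OCc1cn(CCCCOc2cc(=O)oc3ccccc23)nn1`: 34%
- compound 3, `COc1cc(/C=C/C(=O)/C=C/c2cc(OC)c(OC)c(OC)c2)ccc1OCc1cn(CCOc2cc(=O)oc3ccccc23)nn1`: 89%

All three were run in a functional assay on HCT-116 cells (Homo sapiens) for inhibition, read by sulforhodamine B assay, with a stated time of 48 h, tested at 50 uM; a higher number here means more inhibition of growth at the concentration tested, a lower number less inhibition of growth. Compound 3 gives the highest number of the three. The gap between compound 3 and compound 1 is beyond the scatter, and the larger gap between compound 3 and compound 2 is also beyond the scatter. Compound 1 and compound 2 differ in one place only, (hydrogen in place of methoxy on an aromatic carbon), and the step of a number 10 percentage points lower from compound 1 to compound 2 (within the scatter) is within the scatter, so no order can be read between those two.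

Compound 3 and compound 1 differ in more than one place; the difference between the two cores is not broken down here.

Compound 4, `COc1ccc(/C=C/C(=O)/C=C/c2ccc(OCc3cn(CCOc4cc(=O)oc5ccccc45)nn3)c(OC)c2)cc1OC`, is not yet measured. Against compound 3 it shows (hydrogen in place of methoxy on an aromatic carbon). Going by the values given here, this is the same kind of change as the one from compound 1 to compound 2, not the same change: in that earlier pair the place is meta to a large group, while here the place is also ortho to a methoxy group and meta to a methoxy group. Among the compounds with values here, with only a single measured step of this kind, the expectation rests on compound 3 at 89% and on the small step of a number 10 percentage points lower from compound 1 to compound 2 (within the scatter). The expected step is a number 14 percentage points lower from compound 3 to compound 4 (beyond the scatter), a little larger than the earlier one because compound 3 starts from 89%, a high number with more room to fall. In this assay compound 4 is expected to give about 75%, with a range from 50% to 92%.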

Compound 4, percent growth inhibition at one concentration: 82%
The estimate for compound 4 lay 7 percentage points below the measured number, and the stated range covers the measured number.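

In this assay, hydrogen in place of methoxy, here 3,4,5-trimethoxyphenyl to 3,4-dimethoxyphenyl, gives a number 7 percentage points lower from compound 3 to compound 4 (within the scatter) on the core of compound 3. Set beside the earlier step, the change reads the same on both cores: the same change on two cores in this assay, a number 10 percentage points lower (within the scatter) from compound 1 to compound 2 and a number 7 percentage points lower (within the scatter) from compound 3 to compound 4, 3 percentage points apart, within the scatter of two such steps. Going by these compounds alone, this shows that, on these two cores, the change gives no step beyond the scatter and that the two steps do not differ, but it rests on only two pairs, with the change at differently substituted places on the aromatic ring, read at a single concentration, so it sets no rule for other cores and gives no measure of how much a methoxy group contributes.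

The compounds shown leave open whether a group other than methoxy or hydrogen at this place, such as an amine or a carboxylic acid, would give a step beyond the scatter. They also leave open how much of the gap between the core of compound 3 and the core of compound 1 comes from the chain joining the triazole-bearing part to the coumarin-type end, since no pair shown differs there alone, and a longer chain on the core of compound 3 would bear on this.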